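Swapping chloro for piperidin-1-yl on a chlorinated lactone core

The compounds below may be only part of what the source reports. "The series", "measured", "known", "first", "only" and "open" are said of these compounds alone.

Three compounds have been measured in an ADME assay on BEAS-2B cells (Homo sapiens) for cytotoxicity, read by MTT assay, with a stated time of 72 h; a lower number here means a stronger inhibitor, a higher number a weaker inhibitor:

Compound 1 `CC(C)OC1OC(=O)C(Cl)=C1N1CCCCC1` gives > 400000 nM, which is a limit of the assay rather than a number.
Compound 2 `CCCCOC1OC(=O)C(Cl)=C1Cl` gives 22300 nM.
Compound 3 `CCOC1OC(=O)C(Cl)=C1Cl` gives 3800 nM.

Among the two plain numbers, compound 2 stands highest, and compound 3 gives the lower one. Going by the values given here, the only measured step between neighbours is a 5.9-fold lower number from compound 2 to compound 3 (0.77 log units; beyond the scatter), a modest change that comes from hydrogen in place of ethyl on the saturated chain. For compound 1 the assay reports only (the limit of > 400000 nM in this assay, at which 1 of the 3 values shown sits).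

Compound 4 `CCCCOC1OC(=O)C(Cl)=C1N1CCCCC1` has not yet been measured in this assay. It differs from compound 2 in one place: piperidin-1-yl in place of chloro on a double-bonded ring carbon. Among the compounds with values here, no measured step covers this exchange; the single measured step alters the chain and leaves the ring carbon untouched, so it offers no guide to size or direction here. Within the data shown here, what the data do show is that compound 1, the one compound carrying piperidin-1-yl, reaches only a limit.

On that basis compound 4 is expected to be a weak inhibitor, with an estimated value of 250000 nM and a likely range from 50000 nM to 1000000 nM. The step this estimate implies, an 11-fold higher number from compound 2 to compound 4 (1.05 log units; beyond the scatter), is expected to be a large move toward a higher number, quite possibly ending at a limit.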

Compound 4, half-maximal inhibitory concentration: 172000 nM
Estimate against measurement, compound 4: 1.5-fold (0.16 log units) above, within the range that was stated.
By their numbers in this assay, from the lowest: compound 3; then compound 2; then compound 4. At a limit, above all of these: compound 1.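

In this assay, the exchange of chloro for piperidin-1-yl on this double-bonded ring carbon now has a measured size (a 7.7-fold higher number from compound 2 to compound 4 (0.89 log units; beyond the scatter)), so the ring carbon, and not only the chain on the oxygen, moves the number. With piperidin-1-yl held in place, the group on the oxygen still matters, and butyl in place of isopropyl gives a step that can be read only in one direction and only as a minimum (an at least 2.3-fold lower number from compound 1 to compound 4 (0.36 log units; beyond the scatter)). That step has no exact size, as compound 1 stands at a limit of the assay and not at a number: the limit of > 400000 nM in this assay, at which 1 of the 4 values shown sits.

The compounds shown leave open whether piperidin-1-yl is special at this ring carbon or whether another amine, such as morpholine or dimethylamine, would move the number as far. They also leave open whether the exchange has a similar size with the ethyl group of compound 3 on the oxygen, and whether a longer chain such as hexyl would carry the number higher than butyl does in compound 2.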